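Amino for diethylamino: a cytotoxicity limit

The compounds below may be only part of what the source reports. "The series", "measured", "known", "first", "only" and "open" are said of these compounds alone.

In an ADME assay on BJ cells (Homo sapiens) for cytotoxicity, with a stated time of 72 h (on this read-out lower numbers stand for an effect already at smaller amounts and higher numbers for an effect only at larger amounts of compound), compound 1 (`COc1ccc2ncnc(-n3nc(-c4ccccn4)nc3N)c2c1`) gives > 27000 nM as a limit, not a number. Among the measured compounds shown here, compound 2 (`CCN(CC)c1nc(-n2nc(-c3ccccn3)nc2N)c2cc(OC)c(OC)cc2n1`) gives > 9000 nM as a limit too, so its standing is known only as a limit, as is the one other value. Compound 3 (`COc1cc2nc(N)nc(-n3nc(-c4ccccn4)nc3N)c2cc1OC`) has amino in place of diethylamino on an aromatic carbon. For the measured compounds named here, no measured pair shows the size of this change. In this assay the expected step that the limit leaves unreadable from compound 2 to compound 3 is none beyond the usual scatter. Compound 3 is estimated at 15000 nM with 6000 nM to 40000 nM as the expected range.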

Compound 3, half-maximal effective concentration: > 27000 nM
Compound 3: only a limit was reported; the forecaster's own chance of this, stated with the estimate: 70%; middle value at least 1.8-fold (0.25 log units) from the limit.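

Among the compounds shown here, compound 2 and compound 3 both give only limits, not numbers, so no step between them can be read. The compounds shown leave open at what concentration any of them becomes toxic to the cells.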